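Methyl in place of 3-hydroxyphenyl on a sulfonyl sulfur

The source may hold more compounds than are shown below. What is called first, only, known or untested is meant among the compounds shown, and "the series" means these compounds.

compound 1 `O=S(=O)(Nc1ccc2oc(-c3ccccc3)nc2c1)c1cccc(C(F)(F)F)c1`: in an assay on isolated protein for inhibition of malate dehydrogenase, mitochondrial (Sus scrofa), with stated times of 45 min and 30 min (on this read-out higher numbers stand for weaker inhibition and lower numbers for stronger inhibition), compound 1 gives > 63000 nM, a limit of the assay.
compound 2 `Cc1ccc(S(=O)(=O)Nc2ccc3oc(-c4ccccc4)nc3c2)cc1`: in this assay compound 2 gives > 63000 nM, a limit of the assay.
compound 3 `O=S(=O)(Nc1ccc2oc(-c3ccccc3)nc2c1)c1cccc(O)c1`: in this assay compound 3 gives > 63000 nM, a limit of the assay.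

Compound 3 stands where every measured compound stands, at the limit of > 63000 nM in this assay, at which 3 of the 3 values shown sit, so no number sets it apart from the other two. The steps leading to it, a step that the two limits leave unreadable from compound 1 to compound 3 and a step that the two limits leave unreadable from compound 2 to compound 3, cannot be read: both of their ends are limits. The unmeasured compound 4 `CS(=O)(=O)Nc1ccc2oc(-c3ccccc3)nc2c1` differs from compound 3 in one place: methyl in place of 3-hydroxyphenyl on a sulfonyl sulfur. Neither measured step bears on this change beyond showing that three different groups on the sulfonyl sulfur all leave the read-out at the limit of this assay. With no readable step in hand, the expectation for compound 4 is again no readable step, and compound 4 is expected most likely to return a limit once more. The step that the limit leaves unreadable from compound 3 to compound 4 is therefore an estimate, not a reading from the data. Compound 4 is estimated at 100000 nM, in a range from 30000 nM to 400000 nM.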

Compound 4, half-maximal inhibitory concentration: > 63000 nM
Compound 4 ended at the assay's limit; the forecaster's own chance of this, stated with the estimate: 85%; the middle value lies beyond the limit too.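

The steps from compound 2 and from compound 3 to compound 4 cannot be read, since both ends of each step are limits: the limit of > 63000 nM in this assay, at which 4 of the 4 values shown sit.

The compounds shown leave open how far beyond that limit any of them lies, and whether any group on the sulfonyl sulfur of the shared core would give a readable value in this assay.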